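The source may report more compounds than this note shows. Statements on the series, on what has been measured and on what is new or still open speak of the compounds shown alone.

Of the compounds shown here, three sharing one core have been tested in a functional assay on RAW264.7 cells (Mus musculus) for inhibition, read by ELISA, with a stated time of 24 h; a higher number here means that more compound is needed for the effect, a lower number that less compound is needed: compound 1 `CC/C=C\C[C@H]1C(=O)C=C[C@H]1CC(=O)OCC` gives 20000 nM, compound 2 `CC/C=C\C[C@H]1C(=O)C=C[C@H]1CC(=O)OCCCC` gives 23000 nM, and compound 3 `CC/C=C\C[C@H]1C(=O)C=C[C@H]1CC(=O)OCCOCCOCCO` gives 42000 nM. Compound 3 stands apart from only one of the other two: the data show a 2.1-fold higher number from compound 1 to compound 3 (0.32 log units; beyond the scatter), but only a 1.8-fold higher number from compound 2 to compound 3 (0.26 log units; within the scatter).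

Compound 4 `CC/C=C\C[C@H]1C(=O)C=C[C@H]1CC(=O)OCCOCCOC` differs from compound 3 as follows: hydrogen in place of hydroxymethyl on a saturated chain carbon bound to an oxygen on a saturated carbon. Cut one bond further out, the same change reads 2-hydroxyethoxy to methoxy.

The two steps above bear on this change, since they also swap groups on that chain, and so does a 1.2-fold higher number from compound 1 to compound 2 (0.06 log units; within the scatter). All three are small, and only one passes the scatter, modestly. A large move is therefore not expected, only a slight drift towards the numbers of compound 1 and compound 2. The expected step is a 1.4-fold lower number from compound 3 to compound 4 (0.15 log units; within the scatter), which would not clearly separate the two compounds.

In this assay the estimated value for compound 4 is 30000 nM, with an expected range from 16000 nM to 60000 nM.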

Compound 4, half-maximal effective concentration: 33000 nM
The estimate for compound 4 lay 1.1-fold (0.04 log units) below the measured number; measured number inside the range.
By their numbers in this assay, from the lowest: compounds 1, 2, 4 and 3 (each within the scatter of the next, the first and the last beyond it).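

In this assay, taking away the hydroxymethyl at this place, and with it one hydrogen-bond donor and one hydrogen-bond acceptor, gives a 1.3-fold lower number from compound 3 to compound 4 (0.10 log units; within the scatter) and so stays within the scatter: the end of this chain tolerates the swap of 2-hydroxyethoxy for methoxy without a clear change. Compound 4 also stays within the scatter of both compounds with simpler chains, showing a 1.4-fold higher number from compound 2 to compound 4 (0.16 log units; within the scatter) and a 1.7-fold higher number from compound 1 to compound 4 (0.22 log units; within the scatter) as its steps, so unlike compound 3 it has no step beyond the scatter from compound 1. No measured evidence is available to explain these steps.

These chains all end in simple alkyl, hydroxyl or methoxy groups. From the compounds shown here alone, whether an amine or a carboxylic acid at the chain end, or a much longer chain, would shift the number beyond the scatter remains open.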